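Compound 3: aryl restored in place of cyclobutyl

The compounds below may be only part of what the source reports. "The series", "measured", "known", "first", "only" and "open" are said of these compounds alone.

Compound 2 `COc1cc(N)c(Cl)cc1NC(=O)C1CCN(CC2CCC2)CC1` carries cyclobutyl on the saturated chain carbon bound to the ring amine nitrogen. In a functional assay on the whole organism for antagonist activity, with Mus musculus as the target (on this read-out higher numbers stand for an effect only at larger amounts of compound and lower numbers for an effect already at smaller amounts), compound 2 gives only a limit of the assay, > 10 mg/kg. Compound 2 thus sits at the limit of > 10 mg/kg in this assay, at which 1 of the 2 values shown sits. Compound 1 `COc1cc(N)c(Cl)cc1NC(=O)C1CCN(Cc2cccc(C)c2)CC1` has 3-methylphenyl at that place, and in this assay compound 1 gives 2.4 mg/kg. Among the compounds with values here, the single measured step, an at least 4.1-fold higher number from compound 1 to compound 2 (0.61 log units; beyond the scatter), is known only as a bound for that reason. Compound 3 `COc1cc(N)c(Cl)cc1NC(=O)C1CCN(Cc2ccc(C)c(C)c2)CC1` differs from compound 2 by 3,4-dimethylphenyl in place of cyclobutyl on a saturated chain carbon bound to an amine nitrogen in a ring. Within the data shown here, this change reverses the measured step and adds one further methyl on the aryl; the only evidence bearing on it is that step read backwards. For compound 3 a return to roughly the level of compound 1 is therefore expected, an estimated step of an at least 3.3-fold lower number from compound 2 to compound 3 (0.52 log units; beyond the scatter). The estimate for compound 3 in this assay is 3 mg/kg, with a range from 1.2 mg/kg to 8 mg/kg.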

Compound 3, dose for half-maximal effect: > 8 mg/kg
Compound 3: only a limit was reported (the forecaster's own chance of this, stated with the estimate: 15%); middle value at least 2.6-fold (0.42 log units) from the limit.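

In this assay compound 3 gives only a limit, > 8 mg/kg. An aryl group on the saturated chain carbon bound to an amine nitrogen in a ring is therefore not enough on its own to keep a measurable effect in this assay. The single change of methyl in place of hydrogen on an aromatic carbon brings an at least 3.3-fold higher number from compound 1 to compound 3 (0.52 log units; beyond the scatter), which shows that the read-out at this place depends on the substitution of the aryl and not only on its presence, and compound 1 remains the only compound shown with a number rather than a limit.

The step between compound 2 and compound 3 cannot be read, and cyclobutyl and 3,4-dimethylphenyl cannot be ranked against each other. Open too, as far as these compounds go, is how phenyl without any methyl, or an aryl carrying a methoxy or an amine, would read at this place.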